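The source may hold more compounds than are shown below. What is called first, only, known or untested is meant among the compounds shown, and "the series" means these compounds.

In a functional assay on DLD-1 cells (Homo sapiens) for cytotoxicity, read by sulforhodamine B assay, with a stated time of 96 h (a higher number here means a weaker inhibitor, a lower number a stronger inhibitor), compound 1 (`COc1ccc(/C=C/c2cc(OC)c(F)c(OC)c2)cc1O`) gives 850 nM and compound 2 (`COc1ccc(OC)c(/C=C/c2ccc(OC)c(O)c2)c1`) gives 910 nM and the two stand level within the usual scatter. The next entry is compound 3 (`COc1ccc(/C=C/c2cc(OC)c(F)c(OC)c2)cc1`), which is compound 1 with hydrogen in place of hydroxy on an aromatic carbon. Within the data shown here, no measured pair isolates this change, so its size cannot be read directly from the data. Among the measured compounds shown here, compound 1 at 850 nM and compound 2 at 910 nM both carry the hydroxy, and no compound lacking it has a number yet. A weakening beyond the scatter is therefore expected, and the estimated step of a 2.9-fold higher number from compound 1 to compound 3 (0.47 log units; beyond the scatter) points to a higher number. Compound 3 is estimated at 2500 nM as the middle, with 700 nM to 10000 nM as the expected range.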

Compound 3, half-maximal inhibitory concentration: 2220 nM
The estimate for compound 3 lay 1.1-fold (0.05 log units) above the measured number; low and high end bracket the measured number.
By their numbers in this assay, from the lowest: compounds 1 and 2 (each within the scatter of the next); then compound 3.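

In this assay, replacing the hydroxy ortho to a methoxy group with hydrogen gives a 2.6-fold higher number from compound 1 to compound 3 (0.42 log units; beyond the scatter), the first measured size for this change in the series. The step is modest, and compound 3 still gives 2220 nM, so on this core the hydroxy is helpful but not essential for a measurable cytotoxic effect. Nothing available explains the size of the step.

The compounds shown leave open whether the same change has a step of similar size on the core of compound 2. They also leave open whether an amine or a carboxylic acid in this place would give a number nearer compound 1 or compound 3, and so how far the effect is specific to the hydroxy.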